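Swapping the amine side chain on a dichlorophenyl pyrazine

The compounds below may be only part of what the source reports. "The series", "measured", "known", "first", "only" and "open" are said of these compounds alone.

Compound 1 `CCOc1nc(-c2ccc(Cl)cc2Cl)c(CC)nc1NC(CC)CC`: 151 nM
Compound 2 `CCc1nc(-c2ccc(Cl)cc2Cl)c(CC)nc1NC(C1CC1)C1CC1`: 3.7 nM
Compound 3 `CCCN(CCN(C)C)c1nc(CC)c(-c2ccc(Cl)cc2Cl)nc1CC`: 1540 nM

In an assay on IMR-32 cells for displacement of a labelled ligand from corticotropin-releasing factor receptor 1 (Homo sapiens), read by scintillation counting, with a stated time of 2 h (on this read-out lower numbers stand for stronger inhibition and higher numbers for weaker inhibition), compound 3 gives the highest number of the three measured compounds, so it is the weakest binder shown; compound 1 sits well below it, and compound 2 lies furthest below. Compound 4 `CCc1nc(-c2ccc(Cl)cc2Cl)c(CC)nc1NC(CC)CC` shares the core of compound 3 and differs from it in one place: (pentan-3-yl)amino in place of (2-(dimethylamino)ethyl)(propyl)amino on an aromatic carbon.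

For the measured compounds named here, only one measured step touches this position. The change a 420-fold higher number from compound 2 to compound 3 (2.62 log units; beyond the scatter) shows that replacing a branched secondary amine at this carbon with the dimethylaminoethyl-bearing tertiary amine weakens binding greatly. Going from compound 3 to compound 4 reverses that kind of change, bringing back a branched secondary amine, though pentan-3-yl rather than dicyclopropylmethyl. Compound 1, which carries the same pentan-3-ylamino group on a core differing only in an ethoxy instead of an ethyl, gives 151 nM, a number far below that of compound 3. A large drop in this assay is therefore expected, a 100-fold lower number from compound 3 to compound 4 (2.01 log units; beyond the scatter), though it may stop short of the number seen for compound 2. Compound 4 is estimated at 15 nM, within the range 4 nM to 60 nM.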

Compound 4, inhibition constant: 4.1 nM
Beside the measured number, compound 4's estimate is 3.7-fold (0.56 log units) above it, and the stated range covers the measured number.
By their numbers in this assay, from the lowest: compounds 2 and 4 (each within the scatter of the next); then compound 1; then compound 3.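

In this assay, the step back to a branched secondary amine (a 380-fold lower number from compound 3 to compound 4 (2.57 log units; beyond the scatter)) shows that the large loss seen with (2-(dimethylamino)ethyl)(propyl)amino is recovered with a simple (pentan-3-yl)amino group, so recovery does not depend on dicyclopropylmethyl. The two rings of dicyclopropylmethyl are not needed for strong binding here, as pentan-3-yl in their place leaves the number within the scatter (a 1.1-fold higher number from compound 2 to compound 4 (0.04 log units; within the scatter)). With (pentan-3-yl)amino held fixed, ethyl in place of ethoxy on an aromatic carbon also counts for much (a 37-fold lower number from compound 1 to compound 4 (1.57 log units; beyond the scatter)), so this amine does not set the number alone.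

Nothing given here explains these shifts. Still open, from the compounds shown here alone, is whether compound 3 owes its weak number to the dimethylamino end or to its tertiary nitrogen, which a dipropylamino group at this carbon could help separate.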